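Hydroxy for Bromo on a Fused Core in Cell Inhibition

The compounds below may be only part of what the source reports. "The series", "measured", "known", "first", "only" and "open" are said of these compounds alone.

In a functional assay on L1210 cells (Mus musculus) for inhibition (a lower number here means a stronger inhibitor, a higher number a weaker inhibitor), compound 3 `Nc1nc2c(nc(Br)n2COCCO)c(=O)[nH]1` gives 355 ug/mL. Of the two plain numbers in hand this is the lower, yet compound 1 `Nc1ccn(COCCO)c(=O)n1` gives 675 ug/mL in this assay, and the gap between them lies within the usual scatter, so the two cannot be told apart. Compound 2 `O=c1[nH]c(=O)n(COCCO)cc1/C=C/Br` reaches only a limit of the assay, > 1000 ug/mL. That single value is the one sitting at the limit of > 1000 ug/mL in this assay, at which 1 of the 3 values shown sits. Within the data shown here, no two of the measured compounds differ in just one place, so there is no measured step to lean on.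

Compound 4 `Nc1nc2c(nc(O)n2COCCO)c(=O)[nH]1` has not yet been measured. It differs from compound 3 in one respect: hydroxy in place of bromo on an aromatic carbon. Among the measured compounds shown here, with no comparable measured step, the size of the change from compound 3 to compound 4 in this assay can only be judged loosely; since every measured value is a weak one, little movement beyond the scatter is expected in either direction, with a slight lean toward a higher number. The estimate for compound 4 in this assay is 550 ug/mL, within a range from 220 ug/mL to 1400 ug/mL, which corresponds to an expected step of a 1.5-fold higher number from compound 3 to compound 4 (0.19 log units; within the scatter).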

Compound 4, concentration for 50% inhibition: > 500 ug/mL
Compound 4: no number, only a limit; the forecaster's own chance of this, stated with the estimate: 35%; the middle value does not contradict the limit.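

Among these compounds, this is the first step measured at this carbon, which lies between two ring nitrogen atoms on the five-membered ring of the fused core: in this assay, hydroxy in place of bromo gives an at least 1.4-fold higher number from compound 3 to compound 4 (0.14 log units; that floor lies within the scatter). Compound 4 is recorded only as a limit of the assay, not as a number: the limit of > 500 ug/mL in this assay, at which 1 of the 4 values shown sits. The change therefore gives no sign that hydroxy makes a stronger inhibitor than bromo at this position, but because the floor of the step lies within the scatter, it does not separate the two groups either.

The compounds shown leave open how far the true value of compound 4 lies from that of compound 3, and so whether this change has any real size at all. They also leave open how an amine, a methyl or a chlorine would read on the same aromatic carbon, and whether a longer chain in place of the (2-hydroxyethoxy)methyl group would move the fused core out of this weak range.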